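A triazine ring on a weakly active lactone core

A few compounds are considered here, and "the series" means these few. Any claim that something is new, unique, unknown or untested is made for them only; others in the source may bear on it.

Compound 1 `NC1(CCn2ncc(=O)[nH]c2=O)OC(=O)C(OCc2ccccc2)=C1OCc1ccccc1`: > 100000 nM
Compound 2 `NC1(CCn2ccc(=O)[nH]c2=O)OC(=O)C(OCc2ccccc2)=C1OCc1ccccc1`: > 100000 nM
Compound 3 `Cc1cn(CCC2(N)OC(=O)C(OCc3ccccc3)=C2OCc2ccccc2)c(=O)[nH]c1=O`: 80400 nM

Among the measured compounds shown here, in a functional assay on MCF7 cells (Homo sapiens) for inhibition, read by MTT assay, with a stated time of 72 h (on this read-out lower numbers stand for stronger inhibition and higher numbers for weaker inhibition), compound 3 gives 80400 nM, the only measured number among the three compounds. Compound 1 reaches only a limit of the assay, > 100000 nM. Compound 2 likewise reaches only a limit, > 100000 nM. Both limits are the same one, (the limit of > 100000 nM in this assay, at which 2 of the 3 values shown sit). The step from compound 1 to compound 2 is therefore unreadable, a step that the two limits leave unreadable from compound 1 to compound 2. The steps that end in compound 3 are readable only as floors: an at least 1.2-fold lower number from compound 1 to compound 3 (0.09 log units; that floor lies within the scatter) and an at least 1.2-fold lower number from compound 2 to compound 3 (0.09 log units; that floor lies within the scatter), and both floors lie within the scatter.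

Compound 4 `NC1(CCn2c(=O)[nH]c(=O)[nH]c2=O)OC(=O)C(OCc2ccccc2)=C1OCc1ccccc1` differs from compound 3 by a group of 9 heavy atoms (3 carbon, 3 nitrogen, 3 oxygen; one six-membered aromatic ring with 3 hetero atoms) in place of a group of 9 heavy atoms (5 carbon, 2 nitrogen, 2 oxygen; one six-membered aromatic ring with 2 hetero atoms), on a saturated chain carbon, two bonds along the chain from a saturated ring carbon. The ring that enters, like the ring of compound 1, carries 3 hetero atoms, and compound 1 sits at the limit (the limit of > 100000 nM in this assay, at which 2 of the 3 values shown sit). The nearest measured step, an at least 1.2-fold lower number from compound 1 to compound 3 (0.09 log units; that floor lies within the scatter), gives no evidence of a change beyond the scatter on exchanging one such ring for another. Compound 4 is thus expected to show no gain over compound 3, and more likely to fall at or beyond the limit again.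

Compound 4 is estimated at 150000 nM, within a range from 50000 nM to 500000 nM. This estimate means a step of a 1.9-fold higher number from compound 3 to compound 4 (0.27 log units; within the scatter), which is expected to lie at the edge of the scatter, if it is read at all.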

Compound 4, half-maximal inhibitory concentration: 84900 nM
Beside the measured number, compound 4's estimate is 1.8-fold (0.25 log units) above it; the measured number falls inside the stated range.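

In this assay, among the compounds shown here, the exchange of the six-membered aromatic ring with 2 hetero atoms for one with 3 hetero atoms, on a saturated chain carbon, two bonds along the chain from a saturated ring carbon, gives a first step between two measured numbers (a 1.1-fold higher number from compound 3 to compound 4 (0.02 log units; within the scatter)), and that step shows no change beyond the scatter. Set against the other two compounds, the new number yields only floors (an at least 1.1-fold lower number from compound 2 to compound 4 (0.07 log units; that floor lies within the scatter) and an at least 1.1-fold lower number from compound 1 to compound 4 (0.07 log units; that floor lies within the scatter)), so neither of these steps shows a change beyond the scatter either. A ring with 3 hetero atoms is therefore compatible with a measured number at this place, whereas compound 1, which also carries such a ring, reaches only a limit, as does compound 2: the limit of > 100000 nM in this assay, at which 2 of the 4 values shown sit.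

Still open, going by these compounds, is whether a group of another kind at this place, such as an amine or a carboxylic acid, or a longer chain between this ring and the shared core, would move the number beyond the scatter. Also open, on these data alone, is whether any change elsewhere on the shared core would do so.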